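Swapping trifluoromethyl for chloro on a transfer-protein inhibitor

The source may report more compounds than this note shows. Statements on the series, on what has been measured and on what is new or still open speak of the compounds shown alone.

In an assay on isolated protein for inhibition of microsomal triglyceride transfer protein large subunit (Homo sapiens) (a higher number here means a weaker inhibitor, a lower number a stronger inhibitor), compound 1 `Cc1cccc(C(=O)Nc2ccc3c(c2)CC(NS(C)(=O)=O)C3)c1-c1ccc(Cl)cc1` gives 100 nM. Compound 2 `COC(=O)NCC1Cc2ccc(NC(=O)c3cccc(C)c3-c3ccc(C(F)(F)F)cc3)cc2C1` gives 24 nM in this assay, the lowest of the two numbers shown, and compound 1 sits beyond the scatter above it. Compound 3 `COC(=O)NCC1Cc2ccc(NC(=O)c3cccc(C)c3-c3ccc(Cl)cc3)cc2C1` differs from compound 2 in one place: chloro in place of trifluoromethyl on an aromatic carbon. Within the data shown here, no measured pair shows this exact change, so the expected step of a 1.7-fold higher number from compound 2 to compound 3 (0.22 log units; within the scatter) is small, within the scatter or a modest weakening. Compound 3 is therefore estimated at 40 nM in this assay, within a range of 15 nM to 110 nM.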

Compound 3, half-maximal inhibitory concentration: 100 nM
Beside the measured number, compound 3's estimate is 2.5-fold (0.40 log units) below it; the measured number falls inside the stated range.
By their numbers in this assay, from the lowest: compound 2; then compounds 1 and 3 (each within the scatter of the next).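

Changing 4-(trifluoromethyl)phenyl to 4-chlorophenyl gives a 4.2-fold higher number from compound 2 to compound 3 (0.62 log units; beyond the scatter) in this assay and so weakens inhibition, which shows that the group at this position matters. With 4-chlorophenyl in place, ((methoxycarbonyl)amino)methyl in place of methanesulfonamido gives no change at the digits printed from compound 1 to compound 3 (within the scatter) and the two groups cannot be told apart. Nothing measured here explains the effect of the swap.

Going by these compounds, whether trifluoromethyl would also strengthen inhibition alongside methanesulfonamido remains open. On these data alone, how a fluoro, methyl or nitrile group would compare at this position is also open.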